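Benzoic acid amides as bile acid receptor agonists: a benzyl variant

The source may report more compounds than this note shows. Statements on the series, on what has been measured and on what is new or still open speak of the compounds shown alone.

Measured compounds:
compound 1, `CCCCOc1ccc(C(=O)Nc2cccc(C(=O)O)c2)cc1`: 105 nM
compound 2, `CC(C)COc1cccc(C(=O)Nc2cccc(C(=O)O)c2)c1`: 1130 nM

In an assay on isolated protein for agonist activity at Bile acid receptor (Homo sapiens), read by TR-FRET, with a stated time of 3 h, in the absence of a further agent (a lower number here means that less compound is needed, a higher number that more compound is needed for the effect), compound 1 gives 105 nM, the lower of the two numbers shown; compound 2 gives 1130 nM, a gap beyond the usual scatter. Compound 3, `Cc1cccc(COc2ccc(C(=O)Nc3cccc(C(=O)O)c3)cc2)c1`, has not been measured. It differs from compound 1 by 3-methylphenyl in place of propyl on a saturated chain carbon bound to an oxygen on an aromatic ring. For the measured compounds named here, no comparable step between measured compounds exists to guide the size of this change. For compound 3 a modest shift toward a lower number is expected, within or just beyond the scatter, giving a 1.8-fold lower number from compound 1 to compound 3 (0.24 log units; within the scatter). Compound 3 is estimated at 60 nM, with a range from 15 nM to 250 nM.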

Compound 3, half-maximal effective concentration: 259 nM
Estimate against measurement, compound 3: 4.3-fold (0.64 log units) below; measured number outside the range, above it.
By their numbers in this assay, from the lowest: compound 1; then compound 3; then compound 2.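

In this assay, swapping propyl for 3-methylphenyl on a saturated chain carbon bound to an oxygen on an aromatic ring gives a 2.5-fold higher number from compound 1 to compound 3 (0.39 log units; beyond the scatter), a modest loss for so much larger a group. An aromatic ring is therefore accepted at this position, although the butoxy chain of compound 1 keeps the lower number. Nothing shown explains this shift.

On these data alone, it remains open whether the methyl contributes, which a plain benzyl group would test. Also open, as far as these compounds go, is how a longer chain, such as hexyl, would compare with butyl.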